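A One-Carbon Extension on the Sulfonyl Side Ring

The source may report more compounds than this note shows. Statements on the series, on what has been measured and on what is new or still open speak of the compounds shown alone.

Measured so far in a functional assay on the whole organism (6C3HED cells, Mus musculus) for inhibition, at a dose of 150 mg/kg by the oral route; on this read-out lower numbers stand for less inhibition and higher numbers for more inhibition at the one dose given (going by the name of the read-out):
Compound 1, `COc1ccc(S(=O)(=O)NC(=O)Nc2ccc(Cl)cc2)s1`, gives 93%.
Compound 2, `CCOc1ccc(S(=O)(=O)NC(=O)Nc2ccc(Cl)cc2)s1`, gives 69%.
Compound 3, `Cc1ccsc1S(=O)(=O)NC(=O)Nc1ccc(Cl)cc1`, gives 17%.

Compounds 1 and 2 share one core and differ in a single place: methyl in place of hydrogen on a saturated chain carbon bound to an oxygen on an aromatic ring. That change gave a number 24 percentage points lower from compound 1 to compound 2 (beyond the scatter). Compound 3 carries a different group on the sulfonyl sulfur, (3-methylthiophen-2-yl in place of 5-methoxythiophen-2-yl on a sulfonyl sulfur), and this brought a number 76 percentage points lower from compound 1 to compound 3 (beyond the scatter), leaving compound 3 with the lowest of the three numbers.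

Compound 4, `CCc1ccsc1S(=O)(=O)NC(=O)Nc1ccc(Cl)cc1`, has not been measured. It differs from compound 3 by methyl in place of hydrogen on a saturated chain carbon bound to an aromatic carbon. Going by the values given here, this is the same kind of change as the one from compound 1 to compound 2, but not the same change: there the added methyl sat on a saturated chain carbon bound to an oxygen on an aromatic ring, here it sits on a saturated chain carbon bound to an aromatic carbon. Among the compounds with values here, only one measured pair shows this kind of step, so the expectation rests on that pair alone.

The step expected here is a number 7 percentage points lower from compound 3 to compound 4 (within the scatter), modest in the same direction, and smaller in size because compound 3 already stands at 17% and the read-out cannot fall much further. For compound 4 the expected value is 10%, with a likely range from 0% to 30%.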

Compound 4, a percentage reported as inhibition, in the whole organism at one dose (the size of the read-out at that dose, not a potency): 21%
The estimate for compound 4 lay 11 percentage points below the measured number; the measured number falls inside the stated range.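

On the core of compound 3, the added methyl, which turns methyl into ethyl, gave a number 4 percentage points higher from compound 3 to compound 4 (within the scatter) in this assay, so the fall seen on the other core did not appear here. Set side by side, the two steps differ: the same change on two cores in this assay, a number 24 percentage points lower (beyond the scatter) from compound 1 to compound 2 and a number 4 percentage points higher (within the scatter) from compound 3 to compound 4, 28 percentage points apart, beyond the scatter of two such steps This shows that the result of this change on one core cannot simply be carried over to the other core in this series. Going by these compounds alone, it does not show why the two results differ, and each core supplies only one pair, with the added methyl on a chain carbon bound to an oxygen in one pair and to an aromatic carbon in the other.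

Changing the whole group on the sulfonyl sulfur remains the far larger effect, with a number 72 percentage points lower from compound 1 to compound 4 (beyond the scatter), yet the compounds shown cannot separate the part played by the methoxy group from the other differences between the two side groups. Also open, on these data alone, is how a longer chain such as propyl, or an amine or a carboxylic acid at the end of the ethyl chain of compound 4, would fare on this core.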